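Cytotoxicity Tolerance of a 3-Chlorophenyl Analogue, Awaiting Measurement

The compounds below may be only part of what the source reports. "The series", "measured", "known", "first", "only" and "open" are said of these compounds alone.

Compound 1, `Cc1ccccc1CNc1nn(-c2ccc(F)cc2F)cc1CNCCN1CCN(C)CC1`, in an ADME assay on Huh-7 cells (Homo sapiens) for cytotoxicity (a higher number here means that more compound is tolerated, a lower number that less compound is tolerated), gives > 20000 nM, which is a limit of the assay.
Compound 2, `Cc1ccccc1-c1nn(-c2ccccc2Cl)cc1CNCCN1CCN(C)CC1`, in this assay gives > 20000 nM, again a limit.

Compound 1 therefore stands at the limit of > 20000 nM in this assay, at which 2 of the 2 values shown sit, and no numbered step between measured compounds exists. Compound 3, `CN1CCN(CCNCc2cn(-c3ccc(F)cc3F)nc2-c2cccc(Cl)c2)CC1`, differs from compound 1 by 3-chlorophenyl in place of (2-methylbenzyl)amino on an aromatic carbon. Because both known values rest at the limit of > 20000 nM in this assay, at which 2 of the 2 values shown sit, no step beyond the scatter is expected in this assay. Compound 3 is expected to give 30000 nM, between 10000 nM and 100000 nM, most probably reported once more as a limit. That estimate means an expected step that the limit leaves unreadable from compound 1 to compound 3, within the usual scatter.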

Compound 3, half-maximal cytotoxic concentration: 15000 nM
For compound 3 the middle estimate is 2.0-fold (0.30 log units) above the measured one, and the stated range covers the measured number.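

Compound 3 is the only compound shown with a value in this assay that is not a limit, so this position now has a readable number. Placing 3-chlorophenyl on this aromatic carbon in place of (2-methylbenzyl)amino gives an at least 1.3-fold lower number from compound 1 to compound 3 (0.12 log units; that floor lies within the scatter). The full size of that step cannot be read because compound 1 rests at a limit: the limit of > 20000 nM in this assay, at which 2 of the 3 values shown sit.

Still open, going by these compounds, is whether the chlorine matters here, and how a plain phenyl or a morpholine on this aromatic carbon would read in this assay.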